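The compounds below may be only part of what the source reports. "The series", "measured", "known", "first", "only" and "open" are said of these compounds alone.

Three cytotoxicity readings share one core. In an ADME assay on HEK293 cells (Homo sapiens) for cytotoxicity, read by MTT assay (on this read-out higher numbers stand for weaker inhibition and lower numbers for stronger inhibition), compound 1 `COc1cc(OC)c(OC)cc1/C=C/C(=O)c1c(O)cc(C)oc1=O` gives 100000 nM. Compound 2 `Cc1cc(O)c(C(=O)/C=C/c2cccc(Br)c2)c(=O)o1` gives 100000 nM in this assay, and compound 3 `Cc1cc(O)c(C(=O)/C=C/c2ccc(Br)cc2)c(=O)o1` gives 100000 nM in this assay. Compound 2 thus stands level with compound 1 and with compound 3 at the digits shown, and none of these three readings differs from another beyond the usual scatter. Compound 4 `CCOc1cccc(/C=C/C(=O)c2c(O)cc(C)oc2=O)c1` has not yet been measured. It differs from compound 2 by ethoxy in place of bromo on an aromatic carbon. Among the measured compounds shown here, no step between two measured compounds covers this change, and the three measured compounds, which carry different groups on that ring, all read the same. In this assay the expected step is no change at the digits printed from compound 2 to compound 4 (within the scatter), none beyond the scatter. For compound 4 the expected value in this assay is 100000 nM, with a range from 40000 nM to 200000 nM.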

Compound 4, half-maximal inhibitory concentration: 80000 nM
For compound 4 the middle estimate is 1.3-fold (0.10 log units) above the measured one, and the stated range covers the measured number.
By their numbers in this assay, from the lowest: compounds 4, 1, 2 and 3 (each within the scatter of the next).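

Ethoxy in place of bromo on this aromatic carbon, meta to a large group, gives a 1.3-fold lower number from compound 2 to compound 4 (0.10 log units; within the scatter) in this assay, the first comparison in which only this group changes. At this position, going from one heavy atom to three and adding a hydrogen-bond acceptor leaves the reading within the scatter. No supporting evidence bears on this result. As far as these compounds go, whether an amine or a carboxylic acid on this carbon, or a chain longer than ethoxy, would move the reading beyond the scatter remains open.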